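Amides of a bicyclic diamine core: ring size at the carbonyl

A few compounds are considered here, and "the series" means these few. Any claim that something is new, unique, unknown or untested is made for them only; others in the source may bear on it.

Measured so far:
compound 1, `CCCC(=O)N1CC2CC(C1)N2`: 92%
compound 2, `O=C(C1CCC1)N1CC2CC(C1)N2`: 80%

In an assay on CHO cells for agonist activity at Neuronal acetylcholine receptor; alpha3/alpha6/beta2/beta3 (Homo sapiens), read by FLIPR and calcium flux (on this read-out higher numbers stand for larger maximal responses and lower numbers for smaller maximal responses), compound 1 gives 92% and compound 2 gives 80%. Among the compounds with values here, the one step known in this assay, a number 12 percentage points lower from compound 1 to compound 2 (beyond the scatter), shows that cyclobutyl in place of propyl on a carbonyl carbon cost a modest amount of maximal response. Within the data shown here, compound 2 thus stands at the lower of the two numbers seen, with compound 1 the only neighbour and sitting above it beyond the scatter.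

The next compound, compound 3, `O=C([C@H]1C[C@H]1F)N1CC2CC(C1)N2`, carries the same core as compound 2 and differs only at the carbonyl substituent: 2-fluorocyclopropyl in place of cyclobutyl on a carbonyl carbon.

Among the measured compounds shown here, no measured step bears directly on a change from cyclobutyl to 2-fluorocyclopropyl; the only guide is that replacing a straight chain by a small ring, as in a number 12 percentage points lower from compound 1 to compound 2 (beyond the scatter), moved this assay by a modest margin. A further small ring exchange is therefore expected to leave the response near that of compound 2, within or just beyond the scatter, so the step of a number 2 percentage points lower from compound 2 to compound 3 (within the scatter) is expected to be small. For compound 3 the estimate is 78%, spanning 60% to 95%.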

Compound 3, largest response reached (Emax), in percent of the reference or control that the assay uses: 130%
Beside the measured number, compound 3's estimate is 52 percentage points below it; measured number above the stated range.
By their numbers in this assay, from the lowest: compound 2; then compound 1; then compound 3.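

In this assay, the carbonyl substituent proves able to raise the maximal response as well as lower it: the step of a number 50 percentage points higher from compound 2 to compound 3 (beyond the scatter) is large, although cyclobutyl and 2-fluorocyclopropyl have equal heavy-atom counts and neither has a hydrogen-bond donor or acceptor. The step of a number 38 percentage points higher from compound 1 to compound 3 (beyond the scatter) also places compound 3 clear of the propyl amide, so a simple reading of straight chain against small ring does not hold: the cyclobutyl amide lies under propyl, while the 2-fluorocyclopropyl amide lies over it. No supporting data accompany these numbers to account for the large rise in maximal response at this position.

From the compounds shown here alone, the change alters ring size, adds fluorine and introduces defined stereocentres all at once, so the share of each in the gain remains open; plain cyclopropyl and the mirror-image 2-fluorocyclopropyl would be the direct comparisons on the shared core. Also open, going by these compounds, is whether a high maximal response extends to other groups on this carbonyl carbon, such as cyclopentyl or a longer chain.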